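Working notes: the step from compound 3 to compound 4

A few compounds are considered here, and "the series" means these few. Any claim that something is new, unique, unknown or untested is made for them only; others in the source may bear on it.

Values in a toxicity assay on HepG2 2.2.15 cells (Homo sapiens) for cytotoxicity, read by CellTiter-Glo; a higher number here means that more compound is tolerated, a lower number that less compound is tolerated:
- compound 1 `N#CC1CC(=O)N(c2cnn3c2CN(C(=O)Nc2cc(F)c(F)c(F)c2)C(C2CC2)C3)C1`: > 200000 nM (a limit)
- compound 2 `Cc1cnc(C2CC(=O)N(c3cnn4c3CN(C(=O)Nc3cc(F)c(F)c(F)c3)C(C3CC3)C4)C2)s1`: 96200 nM
- compound 3 `O=C1CC(c2ncco2)CN1c1cnn2c1CN(C(=O)Nc1cc(F)c(F)c(F)c1)C(C1CC1)C2`: > 200000 nM (a limit)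

Compound 3 has only a limit, and it sits at the limit of > 200000 nM in this assay, at which 2 of the 3 values shown sit. Compound 4 `Cc1nc(C2CC(=O)N(c3cnn4c3CN(C(=O)Nc3cc(F)c(F)c(F)c3)C(C3CC3)C4)C2)no1` carries 5-methyl-1,2,4-oxadiazol-3-yl in place of 1,3-oxazol-2-yl on a saturated ring carbon.

Among the measured compounds shown here, two measured steps bear on this change: an at least 2.0-fold lower number from compound 1 to compound 2 (0.31 log units; beyond the scatter), and an at least 2.0-fold higher number from compound 2 to compound 3 (0.31 log units; beyond the scatter). The third, a step that the two limits leave unreadable from compound 1 to compound 3, gives no size. For the measured compounds named here, compound 2, also with a methyl-bearing ring, is the only guide to a move towards a lower number, and any such move is expected to be small. The expected step is an at least 1.2-fold lower number from compound 3 to compound 4 (0.09 log units; that floor lies within the scatter). Compound 4 is estimated at 160000 nM, with an expected range of 70000 nM to 200000 nM.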

Compound 4, half-maximal cytotoxic concentration: > 200000 nM
Compound 4 gave a limit, no number (the forecaster's own chance of this, stated with the estimate: 60%); middle value at least 1.2-fold (0.09 log units) away from the limit.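

In this assay compound 4 gives > 200000 nM, which is a limit. A methyl on the five-membered aromatic ring is therefore not enough on its own to lower the number at this saturated ring carbon: 5-methyl-1,2,4-oxadiazol-3-yl in place of 5-methyl-1,3-thiazol-2-yl gives an at least 2.0-fold higher number from compound 2 to compound 4 (0.31 log units; beyond the scatter). The steps among the compounds at the limit cannot be read, because they all sit at the same ceiling: the limit of > 200000 nM in this assay, at which 3 of the 4 values shown sit.

Going by these compounds, how the cyano, 1,3-oxazol-2-yl and 5-methyl-1,2,4-oxadiazol-3-yl compounds rank remains open. So does the effect of an amine or a carboxylic acid on this carbon.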